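Replacing the substituted thiophene of compound 3 with a pyrrole

The compounds below may be only part of what the source reports. "The series", "measured", "known", "first", "only" and "open" are said of these compounds alone.

In a functional assay on MV4-11 cells (Homo sapiens) for inhibition, read by resazurin assay, with a stated time of 72 h (on this read-out lower numbers stand for stronger inhibition of growth and higher numbers for weaker inhibition of growth), compound 1 `O=C1NCCC12CCN(c1c(Cl)cncc1-c1cccs1)CC2` gives 480 nM and compound 2 `Cc1ccsc1-c1cncc(Cl)c1N1CCC2(CCNC2=O)CC1` gives 910 nM while compound 3 `Cc1cc(-c2cncc(Cl)c2N2CCC3(CCNC3=O)CC2)sc1C=O` gives 2530 nM as the highest number of the three. The step of a 1.9-fold higher number from compound 1 to compound 2 (0.28 log units; within the scatter) comes with methyl in place of hydrogen on an aromatic carbon. Compound 4 `Cn1cccc1-c1cncc(Cl)c1N1CCC2(CCNC2=O)CC1` has 1-methyl-1H-pyrrol-2-yl in place of 5-formyl-4-methylthiophen-2-yl on an aromatic carbon, a change counted as 1-methyl-1H-pyrrol-2-yl in place of 5-formyl-4-methylthiophen-2-yl on an aromatic carbon in full. The group that leaves goes with two measured steps that bear on this one, a 5.3-fold higher number from compound 1 to compound 3 (0.72 log units; beyond the scatter) and a 2.8-fold higher number from compound 2 to compound 3 (0.44 log units; beyond the scatter) as the nearest guides. For the measured compounds named here, no measured compound carries a pyrrole, so the group that enters rests on no data. Losing the group is therefore expected to bring a modest step to a lower number in this assay of roughly the size of a 2.8-fold higher number from compound 2 to compound 3 (0.44 log units; beyond the scatter) taken in reverse. For compound 4 the estimated value is 850 nM with an expected range of 300 nM to 2200 nM as the plausible span. That estimate means an expected 3.0-fold lower number from compound 3 to compound 4 (0.47 log units; beyond the scatter) overall.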

Compound 4, concentration for 50% growth inhibition: 900 nM
The estimate for compound 4 lay 1.1-fold (0.02 log units) below the measured number; measured number inside the range.
By their numbers in this assay, from the lowest: compounds 1, 4 and 2 (each within the scatter of the next); then compound 3.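

In this assay, for the compounds shown here, the 1-methyl-1H-pyrrol-2-yl group gives a number clear of the one for the 5-formyl-4-methylthiophen-2-yl group (a 2.8-fold lower number from compound 3 to compound 4 (0.45 log units; beyond the scatter)), so this place on the aromatic ring also tolerates a five-membered ring that is not a thiophene. The new group does not separate from the two simpler thiophenes (a 1.0-fold lower number from compound 2 to compound 4 (0.00 log units; within the scatter); a 1.9-fold higher number from compound 1 to compound 4 (0.27 log units; within the scatter)), which leaves compound 3 as the only one of the four standing apart. Nothing measured here accounts for the higher number of compound 3.

From the compounds shown here alone, whether the formyl group alone, without the ring methyl, goes with that higher number remains open. So does whether a pyrrole lacking its methyl, or a thiophene with an amine or a carboxylic acid in place of the formyl, would move the number beyond the scatter.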